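From ethyl to oxan-4-yl: a step among limits

The source may hold more compounds than are shown below. What is called first, only, known or untested is meant among the compounds shown, and "the series" means these compounds.

Compound 3 `CCNC(=O)c1cc(C(=O)NC)c(=O)n(Cc2ccccc2)c1` gives >= 144 ug/mL in a physicochemical assay for solubility (a higher number here means a more soluble compound, a lower number a less soluble compound), and this is a limit of the assay, not a number. Compound 1 `CNC(=O)c1cc(C(=O)NC2CC2)cn(Cc2ccc(OC)cc2)c1=O` gives >= 143 ug/mL, which is also a limit. Compound 2 `CNC(=O)c1cc(C(=O)NCCCC2CNCCO2)cn(Cc2ccccc2)c1=O` gives >= 194 ug/mL, again a limit. All the values on hand are therefore limits, so compound 3 cannot be ranked against the other two.

Compound 4 `CNC(=O)c1cc(C(=O)NC2CCOCC2)cn(Cc2ccccc2)c1=O` differs from compound 3 at one place: oxan-4-yl in place of ethyl on an amide-type nitrogen. In words, this is oxan-4-yl in place of ethyl on an amide-type nitrogen.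

Within the data shown here, the one measured step available is a step that the two limits leave unreadable from compound 2 to compound 3. Among the measured compounds shown here, it offers no size to carry over to the new change, and no measured step covers this exchange of groups. The expectation therefore rests on the limit of compound 3 at >= 144 ug/mL, and it is for no shift beyond the scatter in this assay, in either direction. The expected step is a step that the limit leaves unreadable from compound 3 to compound 4, an estimate that claims no clear change. Compound 4 is expected at about 165 ug/mL, with an estimated range from 90 ug/mL to 200 ug/mL, and it may well be reported as a limit too.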

Compound 4, solubility: >= 174 ug/mL
Compound 4 ended at the assay's limit; the forecaster's own chance of this, stated with the estimate: 70%; middle value at least 1.0-fold (0.02 log units) from the limit.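

In this assay compound 4 gives >= 174 ug/mL, which is a limit of the assay and not a number. Compound 2 and compound 3 also stand only as limits, so neither step to compound 4 can be read. As far as these compounds go, whether oxan-4-yl in place of ethyl on an amide-type nitrogen makes any real difference in this assay remains open.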